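Swapping a hydroxy-bearing chain for a cyclohexyl ring

The compounds below may be only part of what the source reports. "The series", "measured", "known", "first", "only" and "open" are said of these compounds alone.

Compound 3 `CCC(CO)NC(=O)c1cc2cccc(OC)c2oc1=N` is tested in an assay on HeLa cells for displacement of a labelled ligand from adenosine receptor A3 (Homo sapiens), read by scintillation counting, with a stated time of 180 min, tested at 10 uM (a higher number here means more inhibition at the concentration tested (going by the name of the read-out), a lower number less inhibition), where compound 3 gives 6%. Two close relatives share its core and differ only in the group carried on the amide nitrogen. Compound 1 `COCCNC(=O)c1cc2cccc(OC)c2oc1=N` gives 15%, and compound 2 `COc1cccc2cc(C(=O)NC3CCCC3)c(=N)oc12` gives 20%. Against these, compound 3 sits apart from compound 2 by a number 14 percentage points lower from compound 2 to compound 3 (beyond the scatter), while its separation from compound 1 is only a number 9 percentage points lower from compound 1 to compound 3 (within the scatter); the two ring-free partners, compound 1 and compound 2, differ by a number 5 percentage points higher from compound 1 to compound 2 (within the scatter).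

Compound 4 `COc1cccc2cc(C(=O)NC3CCCCC3)c(=N)oc12` has not yet been measured. The change from compound 3 is cyclohexyl in place of 1-(hydroxymethyl)propyl on an amide-type nitrogen. Among the compounds with values here, the step that bears most directly on it is the one between compound 2 and compound 3, since a saturated carbon ring again replaces the 1-(hydroxymethyl)propyl chain, only one ring carbon larger. Read backwards, that step points to a modest rise beyond the scatter; the step from compound 1 to compound 2 adds little either way.

Compound 4 is therefore estimated at 20%, with a likely range from 8% to 33%. The step from compound 3 to compound 4 is expected to be a number 14 percentage points higher from compound 3 to compound 4 (beyond the scatter).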

Compound 4, a percentage reported as inhibition, at one concentration (the size of the read-out at that concentration, not a potency): 16%
For compound 4 the middle estimate is 4 percentage points above the measured one, within the range that was stated.
By their numbers in this assay, from the lowest: compounds 3, 1, 4 and 2 (each within the scatter of the next, the first and the last beyond it).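

In this assay, putting cyclohexyl in place of 1-(hydroxymethyl)propyl on the amide nitrogen gives a difference that stays within the scatter (a number 10 percentage points higher from compound 3 to compound 4 (within the scatter)), even though the entering group has no ring-free chain, no hydroxy and no hydrogen-bond donor or acceptor, so the gap beyond the scatter seen with cyclopentyl is not repeated with this second carbon ring. Compound 4 also cannot be told apart from its cyclopentyl relative (a number 4 percentage points lower from compound 2 to compound 4 (within the scatter)) or from its 2-methoxyethyl relative (a number 1 percentage points higher from compound 1 to compound 4 (within the scatter)), which means that neither ring size nor the choice between a carbon ring and this open chain shows a clear effect here. No measurement is available to explain these results.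

The compounds shown leave open whether the hydroxy group or the rest of the 1-(hydroxymethyl)propyl chain accounts for the gap between compound 2 and compound 3, and a plain sec-butyl group on the same nitrogen would separate the two. They also leave open whether a benzyl group or a longer chain ending in an amine would move the number clearly away from this cluster.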